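Diaryl ether thiazolidinediones: dropping one chloro group

The compounds below may be only part of what the source reports. "The series", "measured", "known", "first", "only" and "open" are said of these compounds alone.

Measured so far in a functional assay for agonist activity at Free fatty acid receptor 1 (Homo sapiens), read by FLIPR, in the presence of a further agent that is not named here; a higher number here means that more compound is needed for the effect, a lower number that less compound is needed:
compound 1 `Cc1ccccc1Oc1ccc(CC2SC(=O)NC2=O)cc1` — 124 nM
compound 2 `Cc1ccc(Oc2ccc(CC3SC(=O)NC3=O)cc2)nc1` — 4470 nM
compound 3 `O=C1NC(=O)C(Cc2ccc(Oc3ccc(Cl)cc3Cl)cc2)S1` — 101 nM

Compound 3 gives the lowest number of the three in this assay; compound 1 lies within the scatter of it, and only compound 2 stands clearly apart with a far higher number. Among the measured compounds shown here, the single measured step, a 36-fold higher number from compound 1 to compound 2 (1.56 log units; beyond the scatter), concerns the exchange of the whole ring on the oxygen and does not touch the change at hand.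

Compound 4 `O=C1NC(=O)C(Cc2ccc(Oc3ccccc3Cl)cc2)S1` differs from compound 3 by hydrogen in place of chloro on an aromatic carbon. For the measured compounds named here, no measured step removes a chloro group, so the expectation rests on analogy: compound 1, which carries only a 2-methylphenyl on the oxygen, gives 124 nM and sits within the scatter of compound 3. A ring with a single group beside the oxygen thus appears to be tolerated, and for compound 4 a change no larger than a 1.5-fold higher number from compound 3 to compound 4 (0.17 log units; within the scatter) is expected in this assay. The estimate for compound 4 is 150 nM, with a range from 60 nM to 400 nM.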

Compound 4, half-maximal effective concentration: 1190 nM
The estimate for compound 4 lay 7.9-fold (0.90 log units) below the measured number; the measured number lies above the stated range.
By their numbers in this assay, from the lowest: compounds 3 and 1 (each within the scatter of the next); then compound 4; then compound 2.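

In this assay the chloro group meta to a chloro group and para to a large group carries real weight: hydrogen in its place gives a 12-fold higher number from compound 3 to compound 4 (1.07 log units; beyond the scatter) and takes compound 4 clearly away from compound 3. A single group on the ring does not by itself settle the number, since chloro in place of methyl gives a 9.6-fold higher number from compound 1 to compound 4 (0.98 log units; beyond the scatter) and compound 1 goes against any reading that two groups are needed. The 2-chlorophenyl ring of compound 4 still improves on the 5-methylpyridin-2-yl ring, with a 3.8-fold lower number from compound 2 to compound 4 (0.57 log units; beyond the scatter) for that exchange, so the loss of the chloro group does not take the series back to the level of compound 2.

Open, from the compounds shown here alone, is whether fluoro, methoxy or trifluoromethyl on this carbon would keep the number close to that of compound 3, and whether methyl there could do the same alongside the methyl group of compound 1. Nothing in the data shown gives a reason for these steps.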